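This account rests on a few compounds, and the source may have more. Where it says the series, first, only, none or still open, it means among the compounds named here.

Working notes on the series in an assay on HEK293 cells for positive allosteric modulation of metabotropic glutamate receptor 3 (Rattus norvegicus), read by thallium flux, with a stated time of 2.5 min; on this read-out lower numbers stand for an effect already at smaller amounts and higher numbers for an effect only at larger amounts of compound.

Of the compounds shown here, three have numbers so far. Compound 1 `Cc1c(OCCCCOc2ccc(C(=O)O)cc2)ccc(C(=O)CC(C)C)c1O` gives 2720 nM, compound 2 `Cc1c(OCCCCOc2ccc(C(=O)O)cc2Cl)ccc(C(=O)CC(C)C)c1O` gives 1140 nM, and compound 3 `Cc1cc(C(=O)O)ccc1OCCCCOc1ccc(C(=O)CC(C)C)c(O)c1C` gives 1850 nM. Compound 3 stands second highest of the three numbers: its nearest neighbour is compound 1, with a 1.5-fold lower number from compound 1 to compound 3 (0.17 log units; within the scatter), and the furthest is compound 2, with a 1.6-fold higher number from compound 2 to compound 3 (0.21 log units; within the scatter), both within the scatter. Among the measured compounds shown here, the only step beyond the scatter is a 2.4-fold lower number from compound 1 to compound 2 (0.38 log units; beyond the scatter), a modest one.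

The next step goes from compound 3 to compound 4 `Cc1c(OCCCCOc2ccc(F)c(C(=O)O)c2)ccc(C(=O)CC(C)C)c1O`. The change is 3-carboxy-4-fluorophenyl in place of 4-carboxy-2-methylphenyl on an oxygen on a saturated carbon. For the measured compounds named here, two measured steps bear on it: the methyl in place of hydrogen on an aromatic carbon, a 1.5-fold lower number from compound 1 to compound 3 (0.17 log units; within the scatter), sits within the scatter, so its removal should matter little; the chloro in place of hydrogen on an aromatic carbon, a 2.4-fold lower number from compound 1 to compound 2 (0.38 log units; beyond the scatter), gave a modest lowering. Going by the values given here, no measured step covers a fluorine or the shift of the carboxy group. The expectation is therefore a step of no more than the scatter, if anything a slight lowering, a 1.1-fold lower number from compound 3 to compound 4 (0.04 log units; within the scatter). Compound 4 is estimated at 1700 nM, within 700 nM to 4500 nM.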

Compound 4, half-maximal effective concentration: 920 nM
For compound 4 the middle estimate is 1.8-fold (0.27 log units) above the measured one, and the stated range covers the measured number.
By their numbers in this assay, from the lowest: compounds 4, 2, 3 and 1 (each within the scatter of the next, the first and the last beyond it).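

At this place, on an oxygen on a saturated carbon, 3-carboxy-4-fluorophenyl holds up well against the unsubstituted 4-carboxyphenyl of compound 1, with a modest step beyond the scatter (a 3.0-fold lower number from compound 1 to compound 4 (0.47 log units; beyond the scatter)). Against the two substituted 4-carboxy groups it cannot be told apart, as both steps stay within the scatter (a 2.0-fold lower number from compound 3 to compound 4 (0.30 log units; within the scatter); a 1.2-fold lower number from compound 2 to compound 4 (0.09 log units; within the scatter)), so in this assay the carboxy group is not tied to the arrangement in 4-carboxyphenyl. Nothing available accounts for these steps.

The fluorine and the new place of the carboxy group enter together, so their shares in the step from compound 1 remain unseparated. Also open, on these data alone, is whether a tetrazole or a primary amide could stand in for the carboxylic acid on this ring, and how a shorter or longer chain would read.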